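Acid in place of nitrile on the side chain

A few compounds are considered here, and "the series" means these few. Any claim that something is new, unique, unknown or untested is made for them only; others in the source may bear on it.

Compound 1 `CS(=O)(=O)CCCn1c(Cn2c(=O)n(C3CC3)c3ccncc32)cc2cc(Cl)ccc21` was run in an ADME assay on HeLa cells (Homo sapiens) for cytotoxicity, read by ATP content, with a stated time of 3 days; a lower number here means that less compound is tolerated, a higher number that more compound is tolerated. In this assay compound 1 gives > 50000 nM, which is a limit of the assay and not a number. Compound 2 `N#CCCCn1c(Cn2c(=O)n(C3CC3)c3ccncc32)cc2cc(Cl)ccc21` gives > 50000 nM in this assay, again a limit rather than a number. Going by the values given here, the step that the two limits leave unreadable from compound 1 to compound 2 is therefore unreadable, and compound 2 stands only at a limit, as does the one further value shown; both sit at the limit of > 50000 nM in this assay, at which 2 of the 2 values shown sit.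

Compound 3 `O=C(O)CCCn1c(Cn2c(=O)n(C3CC3)c3ccncc32)cc2cc(Cl)ccc21` differs from compound 2 by carboxy in place of cyano on a saturated chain carbon, three bonds along the chain from an aromatic nitrogen, the same change read one bond further out as 3-cyanopropyl to 3-carboxypropyl. Only the unreadable step from compound 1 to compound 2 bears on this change, so neither a size nor a direction can be taken from the measured data. The expectation is that compound 3 also sits at the limit, with an expected step of a number no higher from compound 2 to compound 3 (the limit leaves the size open). Compound 3 is accordingly estimated at 50000 nM, within 20000 nM to 100000 nM.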

Compound 3, half-maximal cytotoxic concentration: > 50000 nM
Compound 3 gave a limit, no number; the forecaster's own chance of this, stated with the estimate: 80%; the middle value lies on the limit itself.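

In this assay compound 3 gives > 50000 nM, a limit and not a number. The steps among compound 1, compound 2 and compound 3 cannot be read, as all three sit at one limit: the limit of > 50000 nM in this assay, at which 3 of the 3 values shown sit. From the compounds shown here alone, whether the methylsulfonyl, cyano and carboxy side chains differ at all in this read-out stays open.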